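A few compounds are considered here, and "the series" means these few. Any claim that something is new, unique, unknown or untested is made for them only; others in the source may bear on it.

Measured so far:
compound 1 `CC(C)C(=O)O[C@H]1C[C@@H](C)C=C2C=C[C@H](C)[C@H](CC[C@@H]3C[C@@H](O)CC(=O)O3)C21` — 7.7 nM
compound 2 `CCC(CC)(CC)C(=O)O[C@H]1C[C@@H](C)C=C2C=C[C@H](C)[C@H](CC[C@@H]3C[C@@H](O)CC(=O)O3)C21` — 1.4 nM
compound 3 `CCCCC(=O)O[C@H]1C[C@@H](C)C=C2C=C[C@H](C)[C@H](CC[C@@H]3C[C@@H](O)CC(=O)O3)C21` — 8.7 nM

These three compounds share one core and differ only in the group on the carbonyl carbon of the ester. In an assay for inhibition of 3-hydroxy-3-methylglutaryl-coenzyme A reductase (Rattus norvegicus) (a higher number here means a weaker inhibitor, a lower number a stronger inhibitor), compound 1 gives 7.7 nM, the second highest number of the three; compound 3 sits nearest, with a 1.1-fold higher number from compound 1 to compound 3 (0.05 log units; within the scatter), and compound 2 furthest, with a 5.5-fold lower number from compound 1 to compound 2 (0.74 log units; beyond the scatter). Compound 4 `CC(C)CC(=O)O[C@H]1C[C@@H](C)C=C2C=C[C@H](C)[C@H](CC[C@@H]3C[C@@H](O)CC(=O)O3)C21` is not yet measured. It differs from compound 1 by isobutyl in place of isopropyl on a carbonyl carbon. Within the data shown here, of the measured steps, the one to compound 3 bears most on this change, since butyl and isobutyl are both four-carbon chains, and it stayed within the scatter; only the larger step to compound 2, with 1,1-diethylpropyl, moved the number clearly. A step within the scatter is therefore expected, a 1.1-fold lower number from compound 1 to compound 4 (0.04 log units; within the scatter), and compound 4 is estimated at 7 nM, between 3.5 nM and 14 nM.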

Compound 4, half-maximal inhibitory concentration: 5.4 nM
Beside the measured number, compound 4's estimate is 1.3-fold (0.11 log units) above it; low and high end bracket the measured number.
By their numbers in this assay, from the lowest: compound 2; then compounds 4, 1 and 3 (each within the scatter of the next).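

In this assay, isobutyl and isopropyl on the carbonyl carbon cannot be told apart, with a 1.4-fold lower number from compound 1 to compound 4 (0.15 log units; within the scatter). Isobutyl and butyl cannot be told apart either, with a 1.6-fold lower number from compound 3 to compound 4 (0.21 log units; within the scatter), so branching further along the chain shows no effect here, and only the 1,1-diethylpropyl group stands apart, with a 3.9-fold higher number from compound 2 to compound 4 (0.59 log units; beyond the scatter). Nothing available explains this difference. Still open, from the compounds shown here alone, is whether the lower number of compound 2 needs all three ethyl arms or whether a smaller group such as 1,1-dimethylethyl would give it too. How an amine, a carboxylic acid or a phenyl ring would fare at this carbonyl carbon is also unknown.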